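This account rests on a few compounds, and the source may have more. Where it says the series, first, only, none or still open, it means among the compounds named here.

Working notes on the series

Compound 1 `Oc1ccc(-c2cc(-c3cccc(F)c3)cc(-c3ccccc3O)n2)cc1` carries one 2-hydroxyphenyl group; in a functional assay on DU-145 cells (Homo sapiens) for inhibition (on this read-out lower numbers stand for stronger inhibition and higher numbers for weaker inhibition), compound 1 gives > 50000 nM, which is a limit of the assay rather than a number (the limit of > 50000 nM in this assay, at which 1 of the 3 values shown sits). Compound 2 `Oc1ccc(-c2cc(-c3cccc(F)c3)cc(-c3cccc(O)c3)n2)cc1` gives 2700 nM in this assay. Compound 3 `Oc1ccc(-c2cc(-c3ccccc3F)cc(-c3ccc(O)cc3)n2)cc1` gives 7780 nM in this assay, the higher of the two numbers shown; the nearest value is that of compound 2, which lies lower by a margin beyond the scatter.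

Among the measured compounds shown here, the single measured step, an at least 18-fold lower number from compound 1 to compound 2 (1.26 log units; beyond the scatter), concerns the hydroxyphenyl group and shows that moving its substituent out of the 2-position and into the 3-position removes a large penalty.

Compound 4 `Oc1ccc(-c2cc(-c3cccc(F)c3)cc(-c3ccc(O)cc3)n2)cc1` differs from compound 3 by 3-fluorophenyl in place of 2-fluorophenyl on an aromatic carbon. For the measured compounds named here, no measured pair covers a fluorine moved in this way, so the only guidance is the analogous shift on the hydroxyphenyl ring in an at least 18-fold lower number from compound 1 to compound 2 (1.26 log units; beyond the scatter), which was large; a fluorine substituent is a different group, so a smaller effect in the same direction is expected, at the edge of the scatter. The expected step is a 1.9-fold lower number from compound 3 to compound 4 (0.29 log units; within the scatter). For compound 4 the estimate in this assay is 4000 nM, within a range of 1500 nM to 12000 nM.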

Compound 4, half-maximal inhibitory concentration: 9290 nM
Beside the measured number, compound 4's estimate is 2.3-fold (0.37 log units) below it, within the range that was stated.
By their numbers in this assay, from the lowest: compound 2; then compounds 3 and 4 (each within the scatter of the next). At a limit, above all of these: compound 1.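

Moving the fluorine at the ring position opposite the ring nitrogen, with 3-fluorophenyl in place of 2-fluorophenyl, makes no difference that can be read in this assay (a 1.2-fold higher number from compound 3 to compound 4 (0.08 log units; within the scatter)), so the large shift seen earlier on the hydroxyphenyl ring has no counterpart on the fluorophenyl ring in this pair. With 3-fluorophenyl held fixed, the position of the hydroxyl group still matters: 4-hydroxyphenyl in place of 3-hydroxyphenyl gives a 3.4-fold higher number from compound 2 to compound 4 (0.54 log units; beyond the scatter), and 4-hydroxyphenyl in place of 2-hydroxyphenyl gives an at least 5.3-fold lower number from compound 1 to compound 4 (0.73 log units; beyond the scatter), which places 4-hydroxyphenyl between the other two hydroxyphenyl groups. The second of these steps starts from compound 1, whose value is a limit and not a number: the limit of > 50000 nM in this assay, at which 1 of the 4 values shown sits.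

From the compounds shown here alone, it remains open whether 2-fluorophenyl and 3-fluorophenyl would also stay within the scatter of each other when paired with 3-hydroxyphenyl rather than 4-hydroxyphenyl. Also open, going by these compounds, is how an amine or a carboxylic acid in place of the fluorine would read in this assay, and whether the flat result belongs to this position or only to fluorine.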